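This account rests on a few compounds, and the source may have more. Where it says the series, first, only, none or still open, it means among the compounds named here.

Measured so far:
- In an assay on isolated protein for inhibition of Amine oxidase [flavin-containing] B (Homo sapiens), read by spectrophotometry (a lower number here means a stronger inhibitor, a higher number a weaker inhibitor), compound 1 `Clc1ccc(/C=N/Nc2nc3ccccc3nc2Cc2ccccc2)cc1` gives 84000 nM.
- In this assay compound 2 `Clc1ccccc1/C=N/Nc1nc2ccccc2nc1Cc1ccccc1` gives 87000 nM.

For the measured compounds named here, compound 2 stands as the higher of the two numbers, but its only neighbour is compound 1, and the step of a 1.0-fold higher number from compound 1 to compound 2 (0.02 log units; within the scatter) lies within the scatter, so the two compounds cannot be told apart. Compound 3 `Oc1ccc(/C=N/Nc2nc3ccccc3nc2Cc2ccccc2)cc1` has not yet been measured in this assay. It differs from compound 2 in one place: 4-hydroxyphenyl in place of 2-chlorophenyl on a carbon with a double bond to nitrogen. Going by the values given here, the only measured step, a 1.0-fold higher number from compound 1 to compound 2 (0.02 log units; within the scatter), concerns the same carbon but merely moves the chlorine around the ring; it says nothing about exchanging chlorine for a hydroxyl, and no other pair speaks to that change. With so little to go on, the expected step of a 1.0-fold higher number from compound 2 to compound 3 (0.01 log units; within the scatter) is none beyond the scatter, although the range is kept wide: nothing in the measured set tests a hydroxyl on that carbon. Compound 3 is therefore estimated at 90000 nM in this assay, with a range from 30000 nM to 300000 nM.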

Compound 3, half-maximal inhibitory concentration: 7900000 nM
Estimate against measurement, compound 3: 88-fold (1.94 log units) below; measured number above the stated range.
By their numbers in this assay, from the lowest: compounds 1 and 2 (each within the scatter of the next); then compound 3.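

In this assay, the group on the carbon with a double bond to nitrogen turns out not to be indifferent: moving the chlorine around the ring gave no readable change, yet hydroxy in place of chloro on an aromatic carbon gives a 94-fold higher number from compound 1 to compound 3 (1.97 log units; beyond the scatter) and so makes a much weaker inhibitor. The other comparison points the same way, since 4-hydroxyphenyl in place of 2-chlorophenyl gives a 91-fold higher number from compound 2 to compound 3 (1.96 log units; beyond the scatter) and is also large, so at this position the kind of group on the ring matters far more than where the chlorine sits, at least among these compounds. The counts do show that 4-hydroxyphenyl brings a hydrogen-bond donor and a hydrogen-bond acceptor that the chlorophenyl groups lack, but no measurement here explains why the swap costs so much.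

Still open, from the compounds shown here alone, is whether the hydroxyl itself weakens binding or chlorine strengthens it, a question that a plain phenyl ring could help to settle. A methoxy group or an amine in the same place on the ring would also show whether this large loss is specific to the hydroxyl or extends to other groups.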